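The compounds below may be only part of what the source reports. "The series", "measured", "known", "first", "only" and "open" are said of these compounds alone.

Going by the values given here, in a functional assay (Platelet, plasma) for inhibition, with Homo sapiens as the target (on this read-out lower numbers stand for stronger inhibition and higher numbers for weaker inhibition), two analogues on the shared core have numbers so far. Compound 1 `N#Cc1cc2c(nc1N1CCC(C(=O)NS(=O)(=O)Cc3cccc(F)c3)CC1)COC2=O` gives 70500 nM and compound 2 `N#Cc1cc2c(nc1N1CCC(C(=O)NS(=O)(=O)C3(c4ccccc4)CC3)CC1)COC2=O` gives 4100 nM as the lower of the two. Compound 3 `N#Cc1cc2c(nc1N1CCC(C(=O)NS(=O)(=O)Cc3ccc(C(F)(F)F)cc3)CC1)COC2=O` remains unmeasured. The change at issue is 4-(trifluoromethyl)benzyl in place of 1-phenylcyclopropyl on a sulfonyl sulfur and, in words, 4-(trifluoromethyl)benzyl in place of 1-phenylcyclopropyl on a sulfonyl sulfur.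

Among the compounds with values here, only one measured step bears on this: a 17-fold lower number from compound 1 to compound 2 (1.24 log units; beyond the scatter) for 1-phenylcyclopropyl in place of 3-fluorobenzyl at the same place. That step is large and beyond the scatter. Within the data shown here, compound 3 carries a substituted benzyl group again, so the closest precedent is compound 1 at 70500 nM in this assay and a move back towards higher numbers is expected. Among the measured compounds shown here, no measured compound shows what 4-(trifluoromethyl)benzyl does compared with 3-fluorobenzyl, so the full size of the measured step is not assumed. The expected change is a 5.4-fold higher number from compound 2 to compound 3 (0.73 log units; beyond the scatter) towards weaker inhibition, and this remains an estimate. The estimated value for compound 3 is 22000 nM (expected range 6000 nM to 70000 nM).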

Compound 3, half-maximal inhibitory concentration: 15900 nM
Beside the measured number, compound 3's estimate is 1.4-fold (0.14 log units) above it; the range from low to high includes it.
By their numbers in this assay, from the lowest: compound 2; then compound 3; then compound 1.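

In this assay, the substituent on the aromatic ring matters even when the benzyl link to the sulfonyl sulfur stays the same: 4-(trifluoromethyl)phenyl in place of 3-fluorophenyl on a saturated chain carbon bound to a sulfonyl sulfur gives a 4.4-fold lower number from compound 1 to compound 3 (0.65 log units; beyond the scatter). So the benzyl series is not uniformly poor, although 1-phenylcyclopropyl still holds the advantage, with a 3.9-fold higher number from compound 2 to compound 3 (0.59 log units; beyond the scatter), and compound 2 keeps the lowest number of the three, its steps to both others being beyond the scatter. No measurement in hand accounts for either step, so the differences among these three groups remain unexplained.

Compound 1 and compound 3 differ in both the identity of the ring substituent and where it sits on the ring, so the contribution of each remains unresolved; 3-(trifluoromethyl)benzyl and unsubstituted benzyl would help to separate them. Also open, on these data alone, is whether the 4-trifluoromethyl substituent and the cyclopropyl ring would combine favourably, which 1-[4-(trifluoromethyl)phenyl]cyclopropyl on the sulfonyl sulfur would test directly.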